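The compounds below may be only part of what the source reports. "The series", "measured", "known", "first", "only" and "open" are said of these compounds alone.

Results so far in a functional assay on Bel-7402 cells (Homo sapiens) for inhibition, read by MTT assay, with a stated time of 24 h, tested at 10 ug/mL; on this read-out lower numbers stand for less inhibition of growth and higher numbers for more inhibition of growth at the one concentration tested

Compound 1 `O=C(CCCCC(S)CCS)NO` gives 28.2%
Compound 2 `O=C(CCCCC1CCSS1)Nc1ccc(OC(F)(F)F)cc1` gives 1.24%
Compound 3 `O=C(CCCCC(S)CCS)Nc1ccc(Cl)cc1` gives 1.16%

Compound 3 (1.16%) stands level, within the scatter, with compound 2, while compound 1 (28.2%) lies higher, beyond the scatter. The unmeasured compound 4 `O=C(CCCCC(S)CCS)Nc1ccc(OC(F)(F)F)cc1` differs from compound 3 by trifluoromethoxy in place of chloro on an aromatic carbon, para to a large group (trifluoromethoxy in place of chloro on an aromatic carbon). Among the compounds with values here, no measured pair isolates this change. Compound 2 also carries trifluoromethoxy and gives only 1.24% in this assay, so no step beyond the scatter is expected. The estimated step is small and upward (a number 1.8 percentage points higher from compound 3 to compound 4 (within the scatter)). Compound 4 is therefore expected to give about 3% (estimated range 0% to 12%).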

Compound 4, percent growth inhibition at one concentration: 14.2%
The estimate for compound 4 lay 11.2 percentage points below the measured number, and the stated range ends below it.
By their numbers in this assay, from the lowest: compounds 3 and 2 (each within the scatter of the next); then compound 4; then compound 1.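

In this assay, with the open chain kept, trifluoromethoxy in place of chloro para to a large group gives a number 13 percentage points higher from compound 3 to compound 4 (beyond the scatter) and shows that the number responds to the group at this place. Trifluoromethoxy does not do this on every chain: with it kept, the open chain in place of the five-membered ring gives a number 13 percentage points higher from compound 2 to compound 4 (beyond the scatter) and shows that the rise also depends on the chain. Nothing measured here accounts for either step. Going by these compounds, whether a methoxy or a nitrile at this place would match trifluoromethoxy remains open, as does the effect of a longer chain.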